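From isobutylsulfonyl to methylsulfonyl on a shared core

This account rests on a few compounds, and the source may have more. Where it says the series, first, only, none or still open, it means among the compounds named here.

In an ADME assay on a cell-free system (plasma, Homo sapiens) (on this read-out higher numbers stand for a larger free fraction and lower numbers for a smaller free fraction), compound 1 (`Cc1ccc(S(=O)(=O)NC(C)C)cc1C#Cc1cc(Cl)ccc1OCC(=O)O`) gives 0.004 as its result, and compound 2 (`CC(C)c1ccc(S(C)(=O)=O)cc1C#Cc1cc(Cl)ccc1OCC(=O)O`) gives 0.003 as its result. These two values lie within the usual scatter of each other. Compound 3 (`Cc1ccc(S(=O)(=O)CC(C)C)cc1C#Cc1cc(Cl)ccc1OCC(=O)O`) stands apart, since its entry reads "not determined" (no result reported) and no number places it on this scale.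

Compound 4 (`Cc1ccc(S(C)(=O)=O)cc1C#Cc1cc(Cl)ccc1OCC(=O)O`) differs from compound 3 by hydrogen in place of isopropyl on a saturated chain carbon bound to a sulfonyl sulfur which turns isobutyl into methyl. With no number for compound 3, the step itself has no measured starting point. Compound 2 also carries methylsulfonyl, and its result of 0.003 in this assay is the closest guide, so only a small move towards a larger free fraction, no greater than the scatter, is expected. Compound 4 is estimated at 0.006 with an expected range from 0.003 to 0.014 in this measurement.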

Compound 4, unbound fraction: 0.017
The estimate for compound 4 lay 2.8-fold (0.45 log units) below the measured number; the whole stated range lies below it.
By their numbers in this assay, from the lowest: compounds 2 and 1 (each within the scatter of the next); then compound 4.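

In this assay replacing isopropyl with methyl on an aromatic carbon gives a 5.7-fold higher number from compound 2 to compound 4 (0.75 log units; beyond the scatter) and replacing isopropylamino with methyl on a sulfonyl sulfur gives a 4.3-fold higher number from compound 1 to compound 4 (0.63 log units; beyond the scatter) on the same read-out. Compounds 1 and 2 lie within the scatter of each other and so showed no movement, whereas compound 4, carrying methyl at both places, stands clearly higher than either, which shows that a single change on this core can shift the free fraction beyond the scatter. Nothing measured here accounts for either step.

The steps from compound 3 cannot be read, which leaves the size of the change from isobutylsulfonyl to methylsulfonyl unknown. The compounds shown also leave open how the free fraction would respond to an ethyl group at either place or an amine on the sulfonyl sulfur.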